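Adding a Chloro Group to a Cyclopropylphenyl Isoxazoline

The source may hold more compounds than are shown below. What is called first, only, known or untested is meant among the compounds shown, and "the series" means these compounds.

Measured so far in an ADME assay on cells (Hepatocyte, Homo sapiens) for pharmacokinetics; a higher number here means faster removal of the compound, a lower number slower removal:
compound 1 `COc1nc(C2=NOCC(c3ccc(Cl)cc3)N2)ccc1-n1cnc(C)c1` gives 2 mL/min/kg;
compound 2 `COc1nc(C2=NOCC(c3ccc(C(C)(C)C)cc3)N2)ccc1-n1cnc(C)c1` gives 320 mL/min/kg;
compound 3 `COc1nc(C2=NOCC(c3cccc(C4CC4)c3)N2)ccc1-n1cnc(C)c1` gives 29 mL/min/kg.

Among these three, compound 3 stands second highest: compound 2 lies above it by an 11-fold lower number from compound 2 to compound 3 (1.04 log units; beyond the scatter) read backwards, and compound 1 lies below it by a 15-fold higher number from compound 1 to compound 3 (1.16 log units; beyond the scatter). The unmeasured compound 4 `COc1nc(C2=NOCC(c3ccc(Cl)c(C4CC4)c3)N2)ccc1-n1cnc(C)c1` differs from compound 3 by chloro in place of hydrogen on an aromatic carbon.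

Within the data shown here, two measured steps bear on this change. In the step of a 160-fold higher number from compound 1 to compound 2 (2.20 log units; beyond the scatter) the chloro-bearing compound 1 is the slowest cleared of the set, and a bulkier group raised the number sharply. In the step of a 15-fold higher number from compound 1 to compound 3 (1.16 log units; beyond the scatter) moving from a chlorophenyl to a cyclopropylphenyl also raised the number. Among the measured compounds shown here, compound 4 carries both a chloro group and a cyclopropyl group on the same ring, a pairing no measured compound shows, so the data give no direct precedent. Since compound 1 with chloro alone gives 2 mL/min/kg, a low value, a small chloro group added to compound 3 is not expected to push the number far in either direction.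

Compound 4 is therefore estimated at 25 mL/min/kg, with a range from 8 mL/min/kg to 80 mL/min/kg. This corresponds to an expected step of a 1.2-fold lower number from compound 3 to compound 4 (0.06 log units; within the scatter), within the scatter.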

Compound 4, clearance: 274 mL/min/kg
Beside the measured number, compound 4's estimate is 11-fold (1.04 log units) below it; measured number outside the range, above it.
By their numbers in this assay, from the lowest: compound 1; then compound 3; then compounds 4 and 2 (each within the scatter of the next).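

In this assay, a single chloro ortho to a cyclopropyl group and para to a large group is not a neutral addition: a 9.4-fold higher number from compound 3 to compound 4 (0.98 log units; beyond the scatter), a step beyond the scatter and upward. Chloro alone goes with the slowest removal in this set, but the low number of compound 1 does not persist once cyclopropyl is also on the ring, as a 140-fold higher number from compound 1 to compound 4 (2.14 log units; beyond the scatter) shows. With the two groups together, the number reaches the level of the tert-butyl compound, and a 1.2-fold lower number from compound 2 to compound 4 (0.07 log units; within the scatter) leaves those two compounds indistinguishable in this assay.

No measurement shown here explains why chloro and cyclopropyl together give so much faster removal than either compound carrying only one of them. Going by these compounds, it remains open whether this rise belongs to chloro specifically or would also appear with fluoro, methyl or a nitrile at the same place, and whether chloro has a similar effect on a ring that carries a different neighbouring group, such as methoxy, in place of cyclopropyl.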